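This account rests on a few compounds, and the source may have more. Where it says the series, first, only, none or still open, it means among the compounds named here.

Measured so far:
- compound 1 `COc1ccc([C@@H]2CC(=O)c3c(O)cc(OCc4cn(Cc5ccccc5C(F)(F)F)nn4)cc3O2)cc1O`: 12500 nM
- compound 2 `CCCCn1cc(COc2cc(O)c3c(c2)O[C@H](c2ccc(OC)c(O)c2)C/C3=N\O)nn1`: 8900 nM

Both numbers come from a functional assay on RAW264.7 cells (Mus musculus) for inhibition, read by Griess assay, with stated times of 2 h and 24 h; a higher number here means a weaker inhibitor, a lower number a stronger inhibitor. In this assay compound 1 gives 12500 nM and compound 2 gives 8900 nM; the two values lie within the usual scatter of each other, so neither compound can be called the stronger, and compound 1 simply carries one of two comparable numbers. For the measured compounds named here, compound 1 and compound 2 differ in several places at once, so no single step can be drawn between them and their pair says nothing about any one change.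

Compound 3 `COc1ccc([C@@H]2CC(=O)c3c(O)cc(OCc4cn(Cc5cccc(C#N)c5)nn4)cc3O2)cc1O` is not yet measured. It differs from compound 1 in one place: 3-cyanophenyl in place of 2-(trifluoromethyl)phenyl on a saturated chain carbon bound to an aromatic nitrogen. Nothing measured here speaks to this exchange, and the shared core is kept intact. The step from compound 1 to compound 3 is therefore expected to be small, a 1.1-fold lower number from compound 1 to compound 3 (0.06 log units; within the scatter), with no direction that rises above the scatter. For compound 3 the estimate in this assay is 11000 nM, with a range from 4000 nM to 30000 nM.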

Compound 3, half-maximal inhibitory concentration: 18000 nM
For compound 3 the middle estimate is 1.6-fold (0.21 log units) below the measured one; the measured number falls inside the stated range.
By their numbers in this assay, from the lowest: compounds 2, 1 and 3 (each within the scatter of the next, the first and the last beyond it).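

In this assay, for the compounds shown here, 3-cyanophenyl in place of 2-(trifluoromethyl)phenyl on a saturated chain carbon bound to an aromatic nitrogen gives a 1.4-fold higher number from compound 1 to compound 3 (0.16 log units; within the scatter) and is the first step that can be read at a single place. Within this one pair, the leaving group with its three fluorine atoms and 0 hydrogen-bond acceptors and the entering group with its nitrile and 1 hydrogen-bond acceptor give numbers that cannot be told apart, so this exchange does not separate the two benzyl groups. The group and the printed location on the phenyl ring change together in this step, and no supporting data bear on the result.

A 2-cyanobenzyl and a 3-(trifluoromethyl)benzyl group would separate the group from its location, while an unsubstituted benzyl, or a benzyl carrying a carboxylic acid or an amine, would test whether the numbers at this place can leave the scatter at all. The butyl group of compound 2 also remains unplaced against these benzyl groups, since compound 2 differs from compound 1 and compound 3 in more than one place.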